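The source may report more compounds than this note shows. Statements on the series, on what has been measured and on what is new or still open speak of the compounds shown alone.

In an in vitro ADME assay on microsomes from liver (Homo sapiens) for metabolic stability, tested at 5 uM (a lower number here means that the compound disappears faster, a higher number that the compound lasts longer), compound 1 `CCC(Oc1ccc2c(c1)S(=O)(=O)N=C(c1c(O)c(-c3cccs3)nn(CCC(C)C)c1=O)N2)C(N)=O` gives 0.35 h. Within the data shown here, the only other measured compound, compound 2 `CC(C)CCn1nc(-c2cccs2)c(O)c(C2=NS(=O)(=O)c3cc(OCC#N)ccc3N2)c1=O`, gives 0.25 h in this assay, and the two cannot be told apart, because a 1.4-fold lower number from compound 1 to compound 2 (0.15 log units; within the scatter). Compound 1 therefore stands at one end of a pair of numbers that sit within the scatter of each other.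

Compound 3 `CC(C)CCn1nc(-c2cccs2)c(O)c(C2=NS(=O)(=O)c3cc(-c4cnoc4)ccc3N2)c1=O` has not yet been measured. It differs from compound 1 in one place: 1,2-oxazol-4-yl in place of 1-carbamoylpropoxy on an aromatic carbon. Among the measured compounds shown here, the one measured step that touches the same place, from compound 1 to compound 2, exchanged one group on the aromatic oxygen for another and gave a 1.4-fold lower number from compound 1 to compound 2 (0.15 log units; within the scatter). For the measured compounds named here, the change to compound 3 goes further, since the oxygen itself leaves and a five-membered aromatic ring enters, and no measured pair covers that. With only a within-scatter step at this position to go on, no movement beyond the scatter in this assay is expected for compound 3, that is a 1.2-fold lower number from compound 1 to compound 3 (0.07 log units; within the scatter). Compound 3 is therefore estimated at 0.3 h, with a range from 0.12 h to 0.75 h.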

Compound 3, half-life: 0.5 h
Beside the measured number, compound 3's estimate is 1.7-fold (0.22 log units) below it; low and high end bracket the measured number.
By their numbers in this assay, from the lowest: compounds 2, 1 and 3 (each within the scatter of the next).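

In this assay, the oxygen link on this aromatic carbon proves not to be needed to stay within the scatter: with 1,2-oxazol-4-yl in place of 1-carbamoylpropoxy, the step is a 1.4-fold higher number from compound 1 to compound 3 (0.15 log units; within the scatter), even though the open chain and its oxygen link both leave and a five-membered aromatic ring enters. Among these compounds, the comparison with the smaller oxygen-linked group reads the same way, with 1,2-oxazol-4-yl in place of cyanomethoxy giving a 2.0-fold higher number from compound 2 to compound 3 (0.30 log units; within the scatter), so the earlier pair, which covered only groups joined through oxygen, now extends to a group joined directly through carbon, and no step among the three compounds lies beyond the scatter. Nothing available explains why these three groups cannot be told apart in this assay.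

On these data alone, it remains open whether any group on this aromatic carbon would produce a step beyond the scatter, for example an amine, a carboxylic acid or a six-membered aromatic ring such as pyridine. As far as these compounds go, it is also open whether the same exchanges would stay within the scatter if the rest of the shared core were changed, since all three compounds carry it unaltered.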